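Trimming the Branched Side Chain to a Straight Propyl

The source may hold more compounds than are shown below. What is called first, only, known or untested is meant among the compounds shown, and "the series" means these compounds.

Measured compounds:
- compound 1, `CC(C)(C)OC[C@@H](N)C(=O)N1CCN(CCCOc2ccc(C(=O)C3CC3)cc2)CC1`: 45700 nM
- compound 2, `CC(C)(C)[C@@H](N)C(=O)N1CCN(CCCOc2ccc(C(=O)C3CC3)cc2)CC1`: 19100 nM
- compound 3, `CCCCCC(=O)c1ccc(OCCCN2CCN(C(=O)[C@@H](C)NC(=O)OC(C)(C)C)CC2)cc1`: 10700 nM

All three compounds share a core carrying a phenyl ketone, a three-carbon linker and a piperazine, and they differ in the amino acid residue attached to the piperazine. In an assay for binding affinity to histamine H2 receptor (Homo sapiens) (on this read-out lower numbers stand for stronger inhibition and higher numbers for weaker inhibition), compound 2 gives 19100 nM, which places it apart from compound 1: the step of a 2.4-fold lower number from compound 1 to compound 2 (0.38 log units; beyond the scatter) is beyond the scatter. Among the compounds with values here, compound 3 gives 10700 nM in this assay, and that number and the one for compound 2 lie within the scatter of each other, so no order can be read between them.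

Compound 4, `CCC[C@@H](N)C(=O)N1CCN(CCCOc2ccc(C(=O)C3CC3)cc2)CC1`, has not yet been measured. It differs from compound 2 by propyl in place of tert-butyl on a saturated chain carbon bound to an amine nitrogen and a carbonyl carbon. Within the data shown here, the only measured step at this position is the one from compound 1 to compound 2, which swapped a branched oxygen-containing group for tert-butyl and gave a modest change. Among the measured compounds shown here, no measured pair compares tert-butyl with propyl, so that step gives no direction for the present change. The expected step in this assay is therefore a 1.3-fold higher number from compound 2 to compound 4 (0.10 log units; within the scatter), essentially none beyond the scatter. Compound 4 is estimated at 24000 nM, with a range from 9000 nM to 65000 nM.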

Compound 4, inhibition constant: 60300 nM
For compound 4 the middle estimate is 2.5-fold (0.40 log units) below the measured one; measured number inside the range.
By their numbers in this assay, from the lowest: compounds 3 and 2 (each within the scatter of the next); then compounds 1 and 4 (each within the scatter of the next).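

In this assay, within the data shown here, this is the first direct comparison of propyl with tert-butyl on a saturated chain carbon bound to an amine nitrogen and a carbonyl carbon, and it gives a 3.2-fold higher number from compound 2 to compound 4 (0.50 log units; beyond the scatter): a modest step, but one beyond the scatter, so the two groups are not interchangeable here and tert-butyl carries the lower number. The second reading, ethyl in place of tert-butoxy on a saturated chain carbon, two bonds along the chain from an amine nitrogen and a carbonyl carbon, gives a 1.3-fold higher number from compound 1 to compound 4 (0.12 log units; within the scatter), which is within the scatter, so no order can be read between these two compounds even though their side chains differ in size and one contains an ether oxygen. No measurement at hand bears on what lies behind either result.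

The compounds shown leave open how a longer chain such as pentyl, a ring such as cyclohexyl, or a side chain ending in an amine or a carboxylic acid would compare with tert-butyl at this place. They also leave open whether the gap between tert-butyl and propyl would persist if the shared core were changed elsewhere.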